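Moving a nitro group around the phenyl ring on the triazole

A few compounds are considered here, and "the series" means these few. Any claim that something is new, unique, unknown or untested is made for them only; others in the source may bear on it.

Measured compounds:
compound 1, `COc1ccc(-n2cc(COc3ccc4oc(=O)ccc4c3)nn2)cc1`, 37800 nM
compound 2, `O=c1ccc2cc(OCc3cn(-c4ccccc4Cl)nn3)ccc2o1`, no numerical result
compound 3, `O=c1ccc2cc(OCc3cn(-c4ccccc4[N+](=O)[O-])nn3)ccc2o1`, 55800 nM

Compound 1 and compound 3 share one core and differ only in the group on the triazole nitrogen. In a functional assay on HCT-116 cells (Homo sapiens) for cytotoxicity, read by MTT assay, with a stated time of 48 h (on this read-out lower numbers stand for stronger inhibition and higher numbers for weaker inhibition), compound 1 gives 37800 nM, and compound 3 gives 55800 nM. The step of a 1.5-fold higher number from compound 1 to compound 3 (0.17 log units; within the scatter) shows that swapping the 4-methoxyphenyl for a 2-nitrophenyl changes little. For compound 2, which carries a 2-chlorophenyl at the same place, the outcome in this assay is recorded as "not determined" (no result reported). Compound 3 therefore has the highest of the two numbers available, with compound 1 the nearest and within the scatter of it.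

Compound 4, `O=c1ccc2cc(OCc3cn(-c4ccc([N+](=O)[O-])cc4)nn3)ccc2o1`, is the next step: 4-nitrophenyl in place of 2-nitrophenyl on an aromatic nitrogen. The nitro group stays, only its position on the phenyl ring moves. Going by the values given here, no measured step addresses such a positional move; the only step to hand, from compound 1 to compound 3, replaced the whole group and stayed within the scatter. With that weak precedent, compound 4 is expected to land close to compound 3, with the step of a 1.1-fold lower number from compound 3 to compound 4 (0.05 log units; within the scatter) estimated to stay within the scatter. For compound 4 the estimate in this assay is 50000 nM, with a range from 20000 nM to 150000 nM.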

Compound 4, half-maximal inhibitory concentration: 44300 nM
Compound 4: middle estimate off by 1.1-fold (0.05 log units), on the high side, within the range that was stated.
By their numbers in this assay, from the lowest: compounds 1, 4 and 3 (each within the scatter of the next).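

Moving the nitro group from the 2-nitrophenyl to the 4-nitrophenyl arrangement tests position on the ring while keeping the group itself, something the earlier compounds could not do. In this assay this move gives a 1.3-fold lower number from compound 3 to compound 4 (0.10 log units; within the scatter), so these two placements of the nitro group cannot be told apart in this assay. Going by these compounds alone, compound 4 also allows a cleaner comparison than the earlier step, as only one group on the ring differs when nitro takes the place of methoxy at the same ring position, and that exchange gives a 1.2-fold higher number from compound 1 to compound 4 (0.07 log units; within the scatter), so nitro and methoxy cannot be told apart here either. Nothing measured on these compounds bears on why they read so alike.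

On these data alone, whether an amine or a carboxylic acid on the phenyl ring would shift the number beyond the scatter remains open. So does the effect of replacing the phenyl ring with a longer chain, and of changing the shared core rather than the group on the ring nitrogen.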